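A few compounds are considered here, and "the series" means these few. Any claim that something is new, unique, unknown or untested is made for them only; others in the source may bear on it.

Compound 1 `FC(F)(F)c1ccc(CSc2nc(Nc3ccccc3)c3ccccc3n2)cc1`: in a functional assay on MDA-MB-231 cells (Homo sapiens) for cytotoxicity, read by MTT assay, with a stated time of 72 h (on this read-out lower numbers stand for stronger inhibition and higher numbers for weaker inhibition), compound 1 gives 18400 nM.
Compound 2 `CCOc1ccccc1Nc1nc(SCc2ccc(C(F)(F)F)cc2)nc2ccccc12`: in this assay compound 2 gives only a limit of the assay, > 50000 nM.

Compound 2 therefore stands at the limit, the weaker of the two, because the step of an at least 2.7-fold higher number from compound 1 to compound 2 (0.43 log units; beyond the scatter) lies beyond the scatter. Compound 3 `COc1cc(Nc2nc(SCc3ccc(C(F)(F)F)cc3)nc3ccccc23)cc(OC)c1` differs from compound 2 by 3,5-dimethoxyphenyl in place of 2-ethoxyphenyl on a nitrogen on an aromatic ring. Within the data shown here, no measured step covers this exact change; the only step on hand, ethoxy in place of hydrogen on an aromatic carbon, an at least 2.7-fold higher number from compound 1 to compound 2 (0.43 log units; beyond the scatter), pushed the value to the limit (the limit of > 50000 nM in this assay, at which 1 of the 2 values shown sits). Compound 3 is expected to stay weak, with an expected step of an at least 1.2-fold lower number from compound 2 to compound 3 (0.09 log units; that floor lies within the scatter). Compound 3 is estimated at 40000 nM, between 12000 nM and 100000 nM.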

Compound 3, half-maximal inhibitory concentration: 16100 nM
Estimate against measurement, compound 3: 2.5-fold (0.40 log units) above, and the stated range covers the measured number.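

On this nitrogen a substituted phenyl need not cost activity: 3,5-dimethoxyphenyl in place of 2-ethoxyphenyl gives an at least 3.1-fold lower number from compound 2 to compound 3 (0.49 log units; beyond the scatter), so the weakness of compound 2 does not extend to every substituted ring. Set against plain phenyl, 3,5-dimethoxyphenyl makes no difference that stands out in this assay, with a 1.1-fold lower number from compound 1 to compound 3 (0.06 log units; within the scatter). The value of compound 2 is only a limit of the read-out, so the true size of the first step stays unknown: the limit of > 50000 nM in this assay, at which 1 of the 3 values shown sits.

On these data alone, what an amine or a carboxylic acid on this ring would do remains open. Also open, as far as these compounds go, is whether the weakness of compound 2 belongs to the ethoxy group itself or to where it sits.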